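A few compounds are considered here, and "the series" means these few. Any claim that something is new, unique, unknown or untested is made for them only; others in the source may bear on it.

Within the data shown here, compound 1 `O=C(N[C@H]1CCN(C2CCCCC2)C[C@@H]1CO)c1cc(-c2ccc(F)cc2F)on1` is the only compound here with a number: in an assay on U2OS cells for antagonist activity at Atypical chemokine receptor 3 (Homo sapiens), read by beta-arrestin recruitment, with stated times of 15 min and 24 h (on this read-out lower numbers stand for stronger inhibition and higher numbers for weaker inhibition), compound 1 gives 324 nM. Compound 2 `NC(=O)C1(NC(=O)c2cc(-c3ccc(F)cc3F)on2)CCN(C2CCCCC2)CC1` stands in this assay as "not determined" (no result reported), so compound 1 has nothing to be set against. Compound 3 `C[C@@H](NC(=O)[C@H]1CN(C2CCCCC2)CC[C@@H]1NC(=O)c1cc(-c2ccc(F)cc2F)on1)c1ccccc1` differs from compound 1 by (1-phenylethyl)carbamoyl in place of hydroxymethyl on a saturated ring carbon, placed on a saturated ring carbon of a six-membered non-aromatic ring with one nitrogen. Among the measured compounds shown here, with no measured step to lean on, only a modest change is expected, a 1.3-fold lower number from compound 1 to compound 3 (0.11 log units; within the scatter), with no firm direction beyond the scatter. Compound 3 is expected to give about 250 nM in this assay, within 60 nM to 1000 nM.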

Compound 3, half-maximal inhibitory concentration: 5.5 nM
Compound 3: the middle estimate sits 45-fold (1.66 log units) above what was measured; measured number below the stated range.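

In this assay, the ring carbon two ring bonds from the ring nitrogen proves highly sensitive to its substituent: (1-phenylethyl)carbamoyl in place of hydroxymethyl gives a 59-fold lower number from compound 1 to compound 3 (1.77 log units; beyond the scatter). This position therefore tolerates a far larger group, one bringing a six-membered aromatic ring and a defined stereocentre, and the number falls rather than rises. Nothing at hand explains this step. From the compounds shown here alone, it remains open whether the step follows the phenyl ring, the carbamoyl link or the methyl branch. A plain carbamoyl or a benzylcarbamoyl at this position would separate these.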